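A few compounds are considered here, and "the series" means these few. Any claim that something is new, unique, unknown or untested is made for them only; others in the source may bear on it.

Compound 1 `CC1(C)CC12NC(=O)N(NC(=O)c1ccccc1F)C2=O`: 100 mg/kg
Compound 2 `COc1ccc(C(=O)NN2C(=O)NC3(CC3(C)C)C2=O)cc1`: 100 mg/kg
Compound 3 `COc1ccc(C(=O)NN2C(=O)NC3(CC3(C)C)C2=O)cc1OC`: 300 mg/kg

Of the compounds shown here, three sharing the same core have been tested in a functional assay on the whole organism (Hindlimb) for inhibition, with Mus musculus as the target, with a stated time of 0.5 h; a higher number here means that more compound is needed for the effect, a lower number that less compound is needed. Compound 1 gives 100 mg/kg in this assay, and compound 2 gives 100 mg/kg, so the two sit at the same level. Compound 3 gives 300 mg/kg, the highest number of the three, standing a step beyond the scatter above both compound 1 and compound 2.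

Going by the values given here, the one step available within this set is a 3.0-fold higher number from compound 2 to compound 3 (0.48 log units; beyond the scatter), and it is the same kind of change as the one that leads on to compound 4 `COc1cc(C(=O)NN2C(=O)NC3(CC3(C)C)C2=O)cc(OC)c1OC`: methoxy in place of hydrogen on an aromatic carbon. Among the compounds with values here, that earlier step, a modest rise, is the only guide, since a third methoxy has no direct precedent here. The expectation is therefore a further rise in this assay, of about the same size or a little smaller, so a step of a 1.7-fold higher number from compound 3 to compound 4 (0.22 log units; within the scatter) is estimated.

Compound 4 is expected to give 500 mg/kg in this assay, with a likely range from 200 mg/kg to 1500 mg/kg.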

Compound 4, minimum effective dose: 300 mg/kg
Compound 4: middle estimate off by 1.7-fold (0.22 log units), on the high side, within the range that was stated.
By their numbers in this assay, from the lowest: compounds 1 and 2 (each within the scatter of the next); then compounds 3 and 4 (each within the scatter of the next).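

In this assay, a methoxy in place of hydrogen at this position, ortho to a methoxy group and meta to a large group, gives no change at the digits printed from compound 3 to compound 4 (within the scatter). The same kind of change earlier gave a 3.0-fold higher number from compound 2 to compound 3 (0.48 log units; beyond the scatter), so among these compounds adding a methoxy to the aromatic ring does not have one fixed effect: the second addition moves the number beyond the scatter, and the third does not. Nothing available here explains why the two steps differ.

Going by these compounds, it remains open whether this position would behave the same with an amine, a carboxylic acid or a longer chain such as butoxy in place of the methoxy. On these data alone, it also remains open what a methoxy at this position would do on a ring without the other two methoxy groups.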